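The compounds below may be only part of what the source reports. "The series", "measured", "known", "first", "only" and "open" are said of these compounds alone.

In a functional assay on HeLa cells (Homo sapiens) for antiproliferative activity, with a stated time of 24 h (on this read-out lower numbers stand for stronger inhibition and higher numbers for weaker inhibition), two members of this series have so far been examined. Compound 1, `NC(=O)c1c(NC(=O)c2ccc(C(F)(F)F)cc2)sc2c1CCN(Cc1ccccc1F)C2`, carries a trifluoromethyl-substituted benzamide on the shared core together with a fluorobenzyl group on the saturated ring. In this assay compound 1 returns only a limit of the assay, > 50000 nM. Compound 2, `NC(=O)c1c(NC(=O)c2ccccc2)sc2c1CCN(C(=S)Nc1ccccc1Cl)C2`, bears an unsubstituted benzamide and a thiourea linked to a chlorophenyl group. For compound 2 this assay likewise reports only a limit, > 50000 nM. For the measured compounds named here, compound 2 therefore stands where every value shown stands, at the limit of > 50000 nM in this assay, at which 2 of the 2 values shown sit, and no measured step separates it from compound 1.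

Compound 3, `Cc1ccc(C(=O)Nc2sc3c(c2C(N)=O)CCN(C(=S)Nc2ccccc2Cl)C3)cc1`, remains to be measured in this assay. It differs from compound 2 in a single place: methyl in place of hydrogen on an aromatic carbon. Going by the values given here, no step between two measured compounds is available to weigh this change against. With compound 2 sitting at the limit, the step that the limit leaves unreadable from compound 2 to compound 3 is expected to be none beyond the scatter, and the most likely outcome for compound 3 is again a limit rather than a number. For compound 3 the estimate is 60000 nM, with a range from 20000 nM to 200000 nM.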

Compound 3, half-maximal inhibitory concentration: 26300 nM
Estimate against measurement, compound 3: 2.3-fold (0.36 log units) above; the measured number falls inside the stated range.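

In this assay, for the compounds shown here, compound 3 gives 26300 nM, the first value that is a number and not a limit. Methyl in place of hydrogen on an aromatic carbon, para to a large group, therefore brings the thiourea-bearing pair onto the readable part of the scale, and the change reads as an at least 1.9-fold lower number from compound 2 to compound 3 (0.27 log units; that floor lies within the scatter). How far the step truly reaches cannot be read, and whether it goes beyond the scatter stays undecided, because compound 2 has only a limit: the limit of > 50000 nM in this assay, at which 2 of the 3 values shown sit.

Compound 1 differs from compound 3 in more than one place and so cannot be set against it, which leaves the methyl change resting on a single pair. Going by these compounds, whether a methoxy group, a chlorine atom, an amine or a longer chain such as ethyl at the same place on the phenyl ring would give a number like that of compound 3, or a limit like that of compound 2, stays open, as does whether the methyl change would read the same with another group on the saturated ring.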